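Adding a hydroxy group to a weak growth inhibitor

This account rests on a few compounds, and the source may have more. Where it says the series, first, only, none or still open, it means among the compounds named here.

Compound 1 (`COc1cc2c(/C=C3/C(=O)Nc4ccc(Br)cc43)c(Cl)n(C)c2cc1C`) gives 9330 nM
Compound 2 (`COc1cc2c(/C=C3/C(=O)N(C)c4ccccc43)c[nH]c2cc1C`) gives 66100 nM

In a functional assay on NSCLC cells (Homo sapiens) for inhibition, with a stated time of 48 h (on this read-out higher numbers stand for weaker inhibition of growth and lower numbers for stronger inhibition of growth), compound 2 gives 66100 nM as the higher of the two numbers, and its gap to compound 1 lies beyond the scatter. Compound 3 (`COc1cc2c(/C=C3/C(=O)N(C)c4ccc(O)cc43)c[nH]c2cc1C`) has hydroxy in place of hydrogen on an aromatic carbon of compound 2 (hydroxy in place of hydrogen on an aromatic carbon). Among the measured compounds shown here, no measured pair isolates a single change, so this step is uncertain. Compound 1 differs in several places, and its 9330 nM shows only that lower numbers occur among these compounds. A modest move toward stronger inhibition is expected, and the estimated step is a 1.9-fold lower number from compound 2 to compound 3 (0.28 log units; within the scatter) in this read-out. For compound 3 the estimate is 35000 nM with an expected range from 10000 nM to 100000 nM in this test.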

Compound 3, concentration for total growth inhibition: 21900 nM
For compound 3 the middle estimate is 1.6-fold (0.20 log units) above the measured one, and the stated range covers the measured number.
By their numbers in this assay, from the lowest: compound 1; then compound 3; then compound 2.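

In this assay, hydroxy in place of hydrogen on this aromatic carbon gives a 3.0-fold lower number from compound 2 to compound 3 (0.48 log units; beyond the scatter) and so moves growth inhibition measurably toward the stronger side. Among the compounds shown here, this is the first single change that can be read, and it shows that this position tolerates a new group and that the read-out responds to it. Nothing shown gives a reason for this gain. As far as these compounds go, whether an amine or a carboxylic acid on the same carbon would give a larger or smaller step remains open.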